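Dimethylamino on the aromatic ring of compound 1

The source may hold more compounds than are shown below. What is called first, only, known or untested is meant among the compounds shown, and "the series" means these compounds.

Among the measured compounds shown here, in a physicochemical assay for solubility, with a stated time of 24 h, tested at 30 mg/mL (on this read-out lower numbers stand for lower solubility and higher numbers for higher solubility), compound 1 `O=C(CCCCCNc1c(Nc2ccccc2)c(=O)c1=O)NO` gives 2200000 nM, the lowest of the three numbers so far. Compound 2 `C[C@@H](Nc1c(NCCCCCC(=O)NO)c(=O)c1=O)c1ccccc1` gives 39000000 nM, and compound 3 `Cc1ccccc1Nc1c(NCCCCCC(=O)NO)c(=O)c1=O` gives 12000000 nM. Compound 4 `CN(C)c1ccc(Nc2c(NCCCCCC(=O)NO)c(=O)c2=O)cc1` is unmeasured and carries dimethylamino in place of hydrogen on an aromatic carbon, para to a large group: dimethylamino in place of hydrogen on an aromatic carbon. For the measured compounds named here, the nearest precedent is the modest methyl step, a 5.5-fold higher number from compound 1 to compound 3 (0.74 log units; beyond the scatter), which also replaces hydrogen on an aromatic carbon. The large step of an 18-fold higher number from compound 1 to compound 2 (1.25 log units; beyond the scatter) changes the whole group on nitrogen and bears less directly. Going by the values given here, no measured compound carries dimethylamino, so a modest rise is expected, with wide uncertainty. The expected step is a 2.7-fold higher number from compound 1 to compound 4 (0.44 log units; beyond the scatter). For compound 4 the estimated value is 6000000 nM, with an expected range of 1800000 nM to 20000000 nM.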

Compound 4, solubility: 1400000 nM
Compound 4: the middle estimate sits 4.3-fold (0.63 log units) above what was measured, outside the stated range (below it).
By their numbers in this assay, from the lowest: compounds 4 and 1 (each within the scatter of the next); then compound 3; then compound 2.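

In this assay, dimethylamino in place of hydrogen on an aromatic carbon, para to a large group, gives a 1.6-fold lower number from compound 1 to compound 4 (0.20 log units; within the scatter) and leaves no separable difference. A change on this aromatic ring therefore need not produce a step beyond the scatter, unlike the methyl change, which gives a 5.5-fold higher number from compound 1 to compound 3 (0.74 log units; beyond the scatter) and does lie beyond it. No measurement available here accounts for the contrast between these two steps.

From the compounds shown here alone, it remains open whether a carboxylic acid or a morpholine ring in this same place would give a step beyond the scatter. Going by these compounds, it also remains open whether methyl in this place would match the methyl step.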